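The source may report more compounds than this note shows. Statements on the series, on what has been measured and on what is new or still open speak of the compounds shown alone.

In a functional assay on KG-1 cells (Homo sapiens) for cytotoxicity, read by luminescence and CellTiter-Glo, with a stated time of 3 days (a higher number here means a weaker inhibitor, a lower number a stronger inhibitor), three compounds have been measured so far:

Compound 1 `Cc1ccc(C(=O)Nc2ccc(C#N)cc2)c(O)c1`: 2560 nM
Compound 2 `O=C(Nc1ccc(OC(F)(F)F)c(Cl)c1)c1ccc(C(F)(F)F)cc1O`: 640 nM
Compound 3 `N#Cc1ccc(NC(=O)c2ccc3cccnc3c2O)cc1`: 2320 nM

Compound 1, at 2560 nM, lies within the scatter of compound 3, while compound 2 gives a lower number, beyond the scatter. Compound 4 `N#Cc1ccc(NC(=O)c2ccc(F)cc2O)cc1` has not yet been measured. It differs from compound 1 by a single exchange, (fluoro in place of methyl on an aromatic carbon), with fluoro in place of methyl on an aromatic carbon. Going by the values given here, no measured pair isolates this exchange, so the data offer no direct guide to it. The expected change is none beyond the scatter, a 1.1-fold higher number from compound 1 to compound 4 (0.04 log units; within the scatter). For compound 4 the estimated value is 2800 nM, with an expected range of 1200 nM to 6500 nM.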

Compound 4, half-maximal inhibitory concentration: 3150 nM
Compound 4: middle estimate off by 1.1-fold (0.05 log units), on the low side; low and high end bracket the measured number.
By their numbers in this assay, from the lowest: compound 2; then compounds 3, 1 and 4 (each within the scatter of the next).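

In this assay, fluoro in place of methyl on this aromatic carbon, meta to a hydroxy group and para to a large group, gives a 1.2-fold higher number from compound 1 to compound 4 (0.09 log units; within the scatter) and so stays within the scatter. Going by these compounds alone, this is the first pair to isolate a single exchange at this position, and the assay does not separate the two groups there. Nothing at hand explains this result.

The compounds shown leave open whether an amine, a carboxylic acid or a longer chain on this carbon would move the number beyond the scatter. As far as these compounds go, compound 2 differs from compound 1 in more than one place, so which part of it goes with its lower number also stays open.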